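A few compounds are considered here, and "the series" means these few. Any claim that something is new, unique, unknown or untested is made for them only; others in the source may bear on it.

Of the compounds shown here, two sharing the same core have so far been tested in a functional assay on MM1.S cells (Homo sapiens) for cytotoxicity, read by MTT assay, with a stated time of 48 h; a lower number here means a stronger inhibitor, a higher number a weaker inhibitor. In this test, compound 1 (`O=C(c1ccc(F)cc1)N(N=C1C(Cl)=C(Cl)C(Cl)=C1Cl)C(=O)c1ccc(F)cc1`) gives 300 nM and compound 2 (`FC(F)(F)c1cccc(NN=C2C(Cl)=C(Cl)C(Cl)=C2Cl)c1`) gives 1000 nM. Compound 2 therefore has the higher of the two numbers, making it the weaker inhibitor, and the gap lies beyond the usual scatter. Compound 3 (`Cc1cccc(NN=C2C(Cl)=C(Cl)C(Cl)=C2Cl)c1`) comes from compound 2 through a single change, with methyl in place of trifluoromethyl on an aromatic carbon. Among the compounds with values here, no measured pair here shows what such a swap does, and compound 1 differs from compound 2 in more than one place. With no firm guide to direction, the expectation in this assay is no change beyond the scatter. The expected step is a 1.1-fold lower number from compound 2 to compound 3 (0.05 log units; within the scatter). Compound 3 is estimated at 900 nM, with an expected range from 300 nM to 2500 nM.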

Compound 3, half-maximal inhibitory concentration: > 3000 nM
Compound 3: a limit, no number; the forecaster's own chance of this, stated with the estimate: 5%; middle value at least 3.3-fold (0.52 log units) from the limit.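

At this place on the ring, meta to a large group, the swap of trifluoromethyl for methyl is not a neutral exchange: in this assay it gives an at least 3.0-fold higher number from compound 2 to compound 3 (0.47 log units; beyond the scatter) and so weakens the result beyond the scatter. Within the data shown here, this is the first change in one place, and it shows that the group sitting here matters for this read-out. The reading for compound 3 is a limit and not a number, so the direction of the step is fixed while its full size stays unknown: the limit of > 3000 nM in this assay, at which 1 of the 3 values shown sits.

From the compounds shown here alone, whether an amine, a carboxylic acid or a longer chain at this place would match or pass compound 2 remains open. Also open, going by these compounds, is whether the same swap would act in the same way on other compounds with the shared core.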